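A few compounds are considered here, and "the series" means these few. Any claim that something is new, unique, unknown or untested is made for them only; others in the source may bear on it.

In a functional assay on DU-145 cells (Homo sapiens) for inhibition, read by trypan blue exclusion, with a stated time of 96 h (a lower number here means a stronger inhibitor of growth, a higher number a weaker inhibitor of growth), compound 1 (`Cc1ccsc1/C=C(/SCc1ccc(Cl)cc1)C(=O)c1ccc(Cl)cc1`) gives 50000 nM and compound 2 (`Cc1ccc(/C=C(/SCc2ccc(Cl)cc2Cl)C(=O)c2ccc(Cl)cc2)s1`) gives 50000 nM. Compound 3 (`Cc1ccsc1/C=C(/SCc1ccc(Cl)c(Cl)c1)C(=O)c1ccc(Cl)cc1`) gives 50000 nM, which places it level with both at the digits shown. Compound 4 (`Cc1ccsc1/C=C(/SCc1ccc(Cl)cc1Cl)C(=O)c1ccc(Cl)cc1`) has not yet been measured. It holds the same atoms as compound 3, joined differently, with 2,4-dichlorophenyl in place of 3,4-dichlorophenyl on a saturated chain carbon bound to a sulfur.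

Within the data shown here, no measured pair isolates this exact change. Among the measured compounds shown here, the one measured step that bears on it, a chloro in place of hydrogen on an aromatic carbon, gave no change at the digits printed from compound 1 to compound 3 (within the scatter). Compound 2 also carries a 2,4-dichlorobenzyl group and gives 50000 nM, although it differs from compound 4 elsewhere in the shared core. On this evidence, no step beyond the scatter is expected in this assay, and the estimated change is no change at the digits printed from compound 3 to compound 4 (within the scatter). For compound 4 the expected value is 50000 nM, with an estimated range of 15000 nM to 70000 nM.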

Compound 4, concentration for 50% growth inhibition: 10000 nM
The estimate for compound 4 lay 5.0-fold (0.70 log units) above the measured number; measured number below the stated range.
By their numbers in this assay, from the lowest: compound 4; then compounds 1, 2 and 3 (each within the scatter of the next).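

In this assay, 2,4-dichlorophenyl in place of 3,4-dichlorophenyl on a saturated chain carbon bound to a sulfur gives a 5.0-fold lower number from compound 3 to compound 4 (0.70 log units; beyond the scatter) here, so this place responds to how the chlorines are arranged, which the earlier level compounds did not show. Chloro in place of hydrogen on an aromatic carbon now has two outcomes, with no change at the digits printed from compound 1 to compound 3 (within the scatter) for one placement and a 5.0-fold lower number from compound 1 to compound 4 (0.70 log units; beyond the scatter) for the other. The 2,4-dichlorobenzyl group does not give this result in every core, as 3-methylthiophen-2-yl in place of 5-methylthiophen-2-yl on a double-bonded chain carbon bound to a double-bonded chain carbon gives a 5.0-fold lower number from compound 2 to compound 4 (0.70 log units; beyond the scatter) in this series.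

Nothing available explains these steps. As far as these compounds go, whether 2,4-difluorophenyl or 2,4-dimethoxyphenyl in the same place would give a similar number remains open.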